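Fluorine Placed on a Benzylamine Ring: Expected Potency Shift

The source may report more compounds than this note shows. Statements on the series, on what has been measured and on what is new or still open speak of the compounds shown alone.

Compound 1, `COc1ccc2nc(C)cc(NCc3ccccc3F)c2c1`: 14000 nM
Compound 2, `COc1ccc2nc(C)cc(NCc3ccc(F)cc3F)c2c1`: 11600 nM
Compound 3, `COc1ccc(CNc2cc(C)nc3ccc(OC)cc23)cc1`: 7000 nM

In a functional assay on MCF-10A cells (Homo sapiens) for antiproliferative activity, with a stated time of 48 h (a higher number here means that more compound is needed for the effect, a lower number that less compound is needed), compound 1 gives 14000 nM, compound 2 gives 11600 nM and compound 3 gives 7000 nM. The change from compound 1 to compound 2 is fluoro in place of hydrogen on an aromatic carbon, and it brought a 1.2-fold lower number from compound 1 to compound 2 (0.08 log units; within the scatter). Compound 4, `COc1ccc2nc(C)cc(NCc3ccc(OC)c(F)c3)c2c1`, is not yet measured; it differs from compound 3 by fluoro in place of hydrogen on an aromatic carbon. This is the same kind of change, but the surroundings differ: in compound 2 the fluoro sits meta to a fluoro group and para to a large group, in compound 4 ortho to a methoxy group and meta to a large group. The difference between the core of compound 1 and the core of compound 3 is not broken down here. Compound 4 is expected to show a 1.2-fold lower number from compound 3 to compound 4 (0.07 log units; within the scatter) in this assay since the earlier change gave a 1.2-fold lower number from compound 1 to compound 2 (0.08 log units; within the scatter). Compound 4 is thus estimated at 6000 nM, between 3000 nM and 13000 nM.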

Compound 4, half-maximal effective concentration: 9000 nM
Compound 4: middle estimate off by 1.5-fold (0.18 log units), on the low side; the measured number falls inside the stated range.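

In this assay, fluoro in place of hydrogen on an aromatic carbon brought a 1.3-fold higher number from compound 3 to compound 4 (0.11 log units; within the scatter). Set beside the earlier step, the new one does not differ from it beyond what repeated measurements allow: the same change on two cores in this assay, a 1.2-fold lower number (0.08 log units; within the scatter) from compound 1 to compound 2 and a 1.3-fold higher number (0.11 log units; within the scatter) from compound 3 to compound 4, 1.6-fold (0.19 log units) apart, within the scatter of two such steps This shows that the change had no readable effect on either core, so the two pairs agree only in that sense; it does not show that an effect of a real size would carry from one core to another, and two pairs are a narrow basis, with the fluoro in different surroundings in each.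

The compounds shown leave open whether a chloro group or a nitrile in the same place would move the number beyond the scatter. They also leave open whether an amine on the ring would behave alike on both cores.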